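Swapping the sulfonyl aryl group: from dichloro to difluoro

A few compounds are considered here, and "the series" means these few. Any claim that something is new, unique, unknown or untested is made for them only; others in the source may bear on it.

Compound 1 `O=S(=O)(c1ccc(F)c(Cl)c1)c1cnc2c(F)cccc2c1-c1ccccc1F` gives 1.39 mL/min in an ADME assay on microsomes from liver (Homo sapiens) for metabolic stability, tested at 2.5 uM; on this read-out higher numbers stand for fast clearance and lower numbers for slow clearance.
Compound 2 `COc1ccc(-c2c(S(=O)(=O)c3cc(Cl)cc(Cl)c3)cnc3c(F)cccc23)cc1` gives 2.11 mL/min in this assay.
Compound 3 `O=S(=O)(c1cc(Cl)cc(Cl)c1)c1cnc2c(F)cccc2c1-c1ccccc1F` gives 0.44 mL/min in this assay.

Compound 3 sits at the bottom of these three numbers, that is, it is the slowest cleared of the set. The two steps that lead to it are both beyond the scatter: a 3.2-fold lower number from compound 1 to compound 3 (0.50 log units; beyond the scatter) and a 4.8-fold lower number from compound 2 to compound 3 (0.68 log units; beyond the scatter). The first of these changes the ring on the sulfonyl sulfur, the second the ring on the aromatic carbon.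

Compound 4 `O=S(=O)(c1ccc(F)c(F)c1)c1cnc2c(F)cccc2c1-c1ccccc1F` differs from compound 3 only on the sulfonyl sulfur: 3,4-difluorophenyl in place of 3,5-dichlorophenyl on a sulfonyl sulfur. Within the data shown here, the step that bears on this is the one from compound 1 to compound 3, where the ring on the sulfonyl sulfur was also exchanged and the number fell by a modest amount. Compound 4 carries a ring closer in kind to that of compound 1 than to the 3,5-dichlorophenyl of compound 3, so a step back upward, of roughly the size seen between compound 1 and compound 3, is expected: a 3.4-fold higher number from compound 3 to compound 4 (0.53 log units; beyond the scatter). Compound 4 is therefore estimated at 1.5 mL/min, with a likely range from 0.6 mL/min to 3.5 mL/min.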

Compound 4, intrinsic clearance in a liver preparation (reported as CLH), per the amount of preparation that the assay uses: 1.39 mL/min
For compound 4 the middle estimate is 1.1-fold (0.03 log units) above the measured one; measured number inside the range.
By their numbers in this assay, from the lowest: compound 3; then compounds 1, 4 and 2 (each within the scatter of the next).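

On the sulfonyl sulfur, the low number of compound 3 in this assay does not carry over to the new ring: 3,4-difluorophenyl in place of 3,5-dichlorophenyl gives a 3.2-fold higher number from compound 3 to compound 4 (0.50 log units; beyond the scatter), which places compound 4 back with compound 1. Exchanging chloro for fluoro on an aromatic carbon of that ring shows no change at the digits printed from compound 1 to compound 4 (within the scatter), so at this one place the swap of halogen leaves the read-out unmoved, and among the three rings tried on the sulfonyl sulfur with the 2-fluorophenyl group kept, only 3,5-dichlorophenyl stands apart. Nothing available here explains why this ring gives the lower number.

The step from compound 3 to compound 4 changes both the kind of halogen and the numbering of the ring at once, so the compounds shown cannot separate these two changes or say which one accounts for the difference. As far as these compounds go, it also remains open how this position would respond to something other than a halogenated phenyl, such as a pyridine ring or a phenyl ring carrying an amine or a carboxylic acid.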